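Opening the ring of compound 2 to a chain amine

The source may hold more compounds than are shown below. What is called first, only, known or untested is meant among the compounds shown, and "the series" means these compounds.

Measured compounds:
- compound 1 `CC(C)=CCc1cc(C(=O)Nc2cc3ccc(OCCC4CCCCN4)c(C)c3oc2=O)ccc1O`: 710 nM
- compound 2 `CC(C)=CCc1cc(C(=O)Nc2cc3ccc(OCC4CCCNC4)c(C)c3oc2=O)ccc1O`: 790 nM
- compound 3 `CCN(CC)CCCOc1ccc2cc(NC(=O)c3ccc(O)c(CC=C(C)C)c3)c(=O)oc2c1C`: 6390 nM

All three share one core and differ only in the amine-bearing side chain on the ether oxygen. In a functional assay on MCF7 cells (Homo sapiens) for antiproliferative activity (a higher number here means a weaker inhibitor, a lower number a stronger inhibitor), compound 2 stands second highest of the three, close to compound 1 and far from compound 3. Compound 4 `CC(C)=CCc1cc(C(=O)Nc2cc3ccc(OCCCNCC(C)C)c(C)c3oc2=O)ccc1O` is not yet measured; it differs from compound 2 in this way: 2-(isobutylamino)ethyl in place of piperidin-3-yl on a saturated chain carbon bound to an oxygen on an aromatic ring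

Among the measured compounds shown here, the closest precedent is an 8.1-fold higher number from compound 2 to compound 3 (0.91 log units; beyond the scatter), where a piperidin-3-yl likewise gave way to a chain amine; a 9.0-fold higher number from compound 1 to compound 3 (0.95 log units; beyond the scatter) shows the same direction. A move to a weaker inhibitor is therefore expected, though compound 4 keeps a hydrogen-bond donor that compound 3 lacks, so a somewhat smaller step is estimated: a 3.8-fold higher number from compound 2 to compound 4 (0.58 log units; beyond the scatter). For compound 4 the expected value is 3000 nM, with a range from 1200 nM to 8000 nM.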

Compound 4, half-maximal inhibitory concentration: 1320 nM
Compound 4: the middle estimate sits 2.3-fold (0.36 log units) above what was measured; measured number inside the range.
By their numbers in this assay, from the lowest: compounds 1, 2 and 4 (each within the scatter of the next); then compound 3.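

In this assay, replacing the ring with an open chain need not matter here: a 1.7-fold higher number from compound 2 to compound 4 (0.22 log units; within the scatter) and a 1.9-fold higher number from compound 1 to compound 4 (0.27 log units; within the scatter) both stay inside the usual scatter. The chain amines themselves do separate, since isobutylamino in place of diethylamino gives a 4.8-fold lower number from compound 3 to compound 4 (0.68 log units; beyond the scatter) and so ties the drop seen for compound 3 to its diethylamino group, not to ring opening alone. No measurement shown accounts for this difference.

Open, on these data alone, is whether a primary amine or a cyclopropylamino group on the same chain would track compound 4. A longer chain carrying isobutylamino also remains untested among these compounds.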